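A few compounds are considered here, and "the series" means these few. Any claim that something is new, unique, unknown or untested is made for them only; others in the source may bear on it.

Working notes on the series. Compound 2, `Cc1nnc(-c2cccc(-c3ccc(C(=O)N(Cc4cccc(OCCCCCC(=O)O)c4)C(C)C)cc3)c2)o1`, is known in an ADME assay on BJ cells (Homo sapiens) for cytotoxicity, read by CellTiter-Glo and resazurin assay, with a stated time of 72 h (on this read-out lower numbers stand for an effect already at smaller amounts and higher numbers for an effect only at larger amounts of compound), only as a limit: in this assay compound 2 gives > 26000 nM. Compound 1, `CC(C)Oc1cccc(-c2ccc(C(=O)N(Cc3cccc(OCCCCCC(=O)O)c3)C(C)C)cc2)c1`, also stops at a limit; in this assay compound 1 gives > 26000 nM. Going by the values given here, the single measured step, a step that the two limits leave unreadable from compound 1 to compound 2, yields no readable size because of the limit of > 26000 nM in this assay, at which 2 of the 2 values shown sit. Compound 3, `CC(C)N(Cc1cccc(OCCCCCC(=O)O)c1)C(=O)c1ccc(-c2ccc3[nH]ccc3c2)cc1`, differs from compound 2 by 1H-indol-5-yl in place of 3-(5-methyl-1,3,4-oxadiazol-2-yl)phenyl on an aromatic carbon. No measured step in this assay bears directly on this change, and the one step shown offers no direction or magnitude to carry over. With both known members of the series sitting at the limit in this assay, compound 3 is expected to remain there as well, which amounts to an expected step that the limit leaves unreadable from compound 2 to compound 3. The estimate for compound 3 in this assay is 30000 nM, with a range from 10000 nM to 100000 nM.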

Compound 3, half-maximal effective concentration: > 26000 nM
Compound 3: no number, only a limit (the forecaster's own chance of this, stated with the estimate: 75%); the middle value does not contradict the limit.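

In this assay compound 3 gives > 26000 nM, a limit and not a number. The steps among compound 1, compound 2 and compound 3 therefore cannot be read: the limit of > 26000 nM in this assay, at which 3 of the 3 values shown sit. The compounds shown leave open whether any change at this aromatic carbon brings the value in this assay off the limit.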